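This account rests on a few compounds, and the source may have more. Where it says the series, first, only, none or still open, it means among the compounds named here.

Compound 1 `CC(C)CSc1nc(CC2CCCCC2)c(C(C)C)c(=O)[nH]1` and compound 3 `CCc1c(CC2CCCCC2)nc(SCC(C)C)[nH]c1=O` share a core and differ in one place: hydrogen in place of methyl on a saturated chain carbon bound to an aromatic carbon and a saturated chain carbon. In an ADME assay on C1866 cells (Homo sapiens) for cytotoxicity, read by MTT assay, with a stated time of 72 h (a higher number here means that more compound is needed for the effect, a lower number that less compound is needed), compound 1 gives 92.9 nM, and compound 3 gives 101 nM; the step of a 1.1-fold higher number from compound 1 to compound 3 (0.04 log units; within the scatter) is small and lies within the scatter of the measurement, so the two numbers are read as alike.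

Compound 2 `CCc1c(CC2CCCCC2)nc(SCC(=O)c2ccc(OC)cc2)[nH]c1=O` carries a different side group on the sulfur, and the difference between its core and that of compound 1 is not broken down here. In this assay compound 2 gives 0.217 nM, the lowest of the three numbers, with compound 1 and compound 3 both far beyond the scatter above it.

Compound 4 `COc1ccc(C(=O)CSc2nc(CC3CCCCC3)c(C)c(=O)[nH]2)cc1` is yet to be measured. It is related to compound 2 by the change (hydrogen in place of methyl on a saturated chain carbon bound to an aromatic carbon). Going by the values given here, this is the same kind of change as the one from compound 1 to compound 3, though the place is not identical: in the earlier pair the saturated chain carbon is bound to an aromatic carbon and a saturated chain carbon, whereas in the new pair it is bound to an aromatic carbon only.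

Because the earlier step of a 1.1-fold higher number from compound 1 to compound 3 (0.04 log units; within the scatter) stayed within the scatter, the step from compound 2 to compound 4 is expected to be of similar size, a 1.4-fold higher number from compound 2 to compound 4 (0.14 log units; within the scatter). Compound 4 is therefore estimated at 0.3 nM, with a likely range from 0.08 nM to 1.2 nM.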

Compound 4, half-maximal effective concentration: 1060 nM
For compound 4 the middle estimate is 3500-fold (3.55 log units) below the measured one; the measured number lies above the stated range.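

In this assay the exchange of ethyl for methyl, with hydrogen taking the place of a methyl on a saturated chain carbon bound to an aromatic carbon, gives a 4900-fold higher number from compound 2 to compound 4 (3.69 log units; beyond the scatter) and so is a large step on the core of compound 2. Carried over from the pair of compound 1 and compound 3, the same kind of change therefore keeps neither its size nor its standing relative to the scatter, and the small step on one core gave no guide to the step on the other: the same change on two cores in this assay, a 1.1-fold higher number (0.04 log units; within the scatter) from compound 1 to compound 3 and a 4900-fold higher number (3.69 log units; beyond the scatter) from compound 2 to compound 4, 4500-fold (3.65 log units) apart, beyond the scatter of two such steps. Going by these compounds alone, this shows that the change cannot simply be transferred between these cores, but it does not show what sets the two steps apart, for the pairs differ both in the side group on the sulfur and in the exact place of the change, and there is only one pair of each kind, so no general rule for the series follows.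

The compounds shown leave open whether the steep step belongs to the side group on the sulfur of compound 2 or to the place of the change itself. They also leave open how a longer chain such as propyl, or a small ring such as cyclopropyl, would read in place of the ethyl of compound 2.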